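One Ring Swap on Compound 1

A few compounds are considered here, and "the series" means these few. Any claim that something is new, unique, unknown or untested is made for them only; others in the source may bear on it.

Measured in a physicochemical assay for solubility, read by nephelometry, measured as kinetic solubility, at pH 6.5; a higher number here means a more soluble compound, a lower number a less soluble compound:
- compound 1 `NCc1csc(NC(=O)c2ccon2)n1` gives 50 ug/mL here
- compound 2 `CC(C)(C)c1cc(C(=O)Nc2ccccn2)n(Cc2ccccc2)n1` gives 6.3 ug/mL here
- compound 3 `NCc1csc(NC(=O)c2ccc(Cl)cc2)n1` gives 25 ug/mL here

Compound 1 lies within the usual scatter of compound 3 and clearly higher than compound 2. Compound 4 `NCc1csc(NC(=O)c2cnn[nH]2)n1` has 1H-1,2,3-triazol-5-yl in place of 1,2-oxazol-3-yl on a carbonyl carbon. Among the compounds with values here, both groups are five-membered aromatic rings, but no measured pair here differs in only one place, so the data offer no direct guide to this swap. In this assay the estimated change is a 1.3-fold lower number from compound 1 to compound 4 (0.10 log units; within the scatter) and so nothing beyond the scatter is expected. For compound 4 the expected solubility is 40 ug/mL with an estimated range from 15 ug/mL to 100 ug/mL across repeat measurements.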

Compound 4, solubility: > 100 ug/mL
Compound 4 gave a limit, no number; the forecaster's own chance of this, stated with the estimate: 10%; at least 2.5-fold (0.39 log units) between middle value and limit.
By their numbers in this assay, from the lowest: compound 2; then compounds 3 and 1 (each within the scatter of the next). At a limit, above all of these: compound 4.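

Compound 4 reads as a limit, not a number, in this assay: the limit of > 100 ug/mL in this assay, at which 1 of the 4 values shown sits. On the carbonyl carbon, 1H-1,2,3-triazol-5-yl in place of 1,2-oxazol-3-yl gives an at least 2.0-fold higher number from compound 1 to compound 4 (0.30 log units; that floor lies within the scatter). This first pair differing in one place shows that a ring carrying a hydrogen-bond donor is accepted here with no loss in the read-out.

Going by these compounds, the real size of the step stays unknown, since only its floor is available. On these data alone, whether a pyrazolyl or tetrazolyl ring on this carbonyl carbon would give a similar reading also remains open.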